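Swapping the aryl amine on a weakly cytotoxic quinazoline thioether

The compounds below may be only part of what the source reports. "The series", "measured", "known", "first", "only" and "open" are said of these compounds alone.

Among the compounds with values here, compound 3 `FC(F)(F)c1ccc(CSc2nc(Nc3cccc(Cl)c3)c3ccccc3n2)cc1` is the only member of this small set with a measured number: in a functional assay on HGC-27 cells (Homo sapiens) for cytotoxicity, read by MTT assay, with a stated time of 72 h (a higher number here means a weaker inhibitor, a lower number a stronger inhibitor), compound 3 gives 19900 nM. Compound 1 `FC(F)(F)c1ccc(CSc2nc(N3CCCCC3)c3ccccc3n2)cc1` reaches only the limit of this assay, at > 50000 nM. Compound 2 `CCOc1ccccc1Nc1nc(SCc2ccc(C(F)(F)F)cc2)nc2ccccc12` likewise stops at a limit, > 50000 nM. Both limits are summarised by the limit of > 50000 nM in this assay, at which 2 of the 3 values shown sit. The step from compound 1 to compound 3 gave an at least 2.5-fold lower number from compound 1 to compound 3 (0.40 log units; beyond the scatter), and the step from compound 2 to compound 3 gave an at least 2.5-fold lower number from compound 2 to compound 3 (0.40 log units; beyond the scatter), so changing the group on that nitrogen has moved the number before. Compound 4 `Cc1ccc(Nc2nc(SCc3ccc(C(F)(F)F)cc3)nc3ccccc23)cc1` differs from compound 3 by 4-methylphenyl in place of 3-chlorophenyl on a nitrogen on an aromatic ring. Within the data shown here, no measured step tests a chlorine-to-methyl swap, so the expected step of a 1.5-fold higher number from compound 3 to compound 4 (0.18 log units; within the scatter) is small and uncertain, and compound 4 is estimated at 30000 nM (range 8000 nM to 100000 nM).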

Compound 4, half-maximal inhibitory concentration: 34600 nM
Estimate against measurement, compound 4: 1.2-fold (0.06 log units) below; the measured number falls inside the stated range.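

In this assay, the swap gives a 1.7-fold higher number from compound 3 to compound 4 (0.24 log units; within the scatter), so a second aryl amine on this nitrogen also gives a real number, and it does so without a chlorine. The other comparisons give only floors, an at least 1.4-fold lower number from compound 2 to compound 4 (0.15 log units; that floor lies within the scatter) and an at least 1.4-fold lower number from compound 1 to compound 4 (0.15 log units; that floor lies within the scatter), so compound 4 cannot be separated from compound 1 or compound 2 here, and the reading stops at a limit: the limit of > 50000 nM in this assay, at which 2 of the 4 values shown sit.

From the compounds shown here alone, it remains open whether a carboxylic acid or an amine on this phenyl ring would move the number beyond the scatter. Compound 3 and compound 4 also change the group and its place together, so the two effects remain unseparated.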